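The source may report more compounds than this note shows. Statements on the series, on what has been measured and on what is new or still open speak of the compounds shown alone.

- compound 1 `O=C1NCCN1c1ccc(S(=O)(=O)Nc2ccc(I)cc2)cc1` gives 260 nM
- compound 2 `O=C1NCCN1c1ccc(S(=O)(=O)Nc2ccc(F)c(F)c2)cc1` gives 220 nM
- compound 3 `CCCCOc1ccc(NS(=O)(=O)c2ccc(N3CCNC3=O)cc2)cc1` has no value yet

In a functional assay on M21 cells (Homo sapiens) for antiproliferative activity, read by sulforhodamine B assay, with a stated time of 48 h (a lower number here means a stronger inhibitor, a higher number a weaker inhibitor), compound 1 and compound 2, the only two measured so far, sit within the scatter of each other. Among the measured compounds shown here, compound 3 keeps the core of compound 1 and carries butoxy in place of iodo on an aromatic carbon as its single change. For the measured compounds named here, the one measured step, a 1.2-fold lower number from compound 1 to compound 2 (0.07 log units; within the scatter), also removes the iodo of compound 1 and stays small. Going by the values given here, no measured compound carries butoxy, so this evidence is thin, and no step beyond the scatter is expected in this assay with wide uncertainty around that expectation. The expected step is a 1.1-fold higher number from compound 1 to compound 3 (0.03 log units; within the scatter) and remains only an estimate. For compound 3 the estimated value is 280 nM with an expected range from 90 nM to 900 nM.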

Compound 3, half-maximal inhibitory concentration: 580 nM
Compound 3: middle estimate off by 2.1-fold (0.32 log units), on the low side; the range from low to high includes it.
By their numbers in this assay, from the lowest: compounds 2 and 1 (each within the scatter of the next); then compound 3.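

The change from iodo to butoxy brings a 2.2-fold higher number from compound 1 to compound 3 (0.35 log units; beyond the scatter) in this assay, the first step among these compounds to lie beyond the scatter. Among the compounds shown here, the only earlier step, a 1.2-fold lower number from compound 1 to compound 2 (0.07 log units; within the scatter), could not show whether the group on this aromatic carbon, para to a large group, matters at all; now it is clear that the group there can shift the number, though only modestly. Butoxy has 5 heavy atoms and 1 hydrogen-bond acceptor where iodo has 1 heavy atom and no acceptor, but no available measurement links the rise to either difference or to anything else.

As far as these compounds go, whether the number keeps rising with chain length remains open, and a shorter methoxy or a longer hexyloxy at this place would test that. How an amine or a carboxylic acid would fare there is also unknown.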